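This account rests on a few compounds, and the source may have more. Where it says the series, first, only, none or still open, it means among the compounds named here.

Measured compounds:
- compound 1 `O=C(Nc1ccc(NC2CCCCC2)cc1Cl)c1cc(Cl)ccc1O`: 68300 nM
- compound 2 `CN(C)c1ccc(NC(=O)c2cc(Cl)ccc2O)c(Cl)c1`: 85100 nM
- compound 3 `O=C(Nc1ccc(NCc2ccc(Br)cc2)cc1Cl)c1cc(Cl)ccc1O`: 40900 nM

All three share one core and differ only in the group on the amino nitrogen of the aniline ring. In an ADME assay on A549 cells (Homo sapiens) for cytotoxicity, read by resazurin assay, with a stated time of 48 h (a lower number here means that less compound is tolerated, a higher number that more compound is tolerated), compound 3 gives the lowest of the three numbers, yet one of the two gaps is small (a 1.7-fold lower number from compound 1 to compound 3 (0.22 log units; within the scatter)), and only the other is modest and beyond the scatter (a 2.1-fold lower number from compound 2 to compound 3 (0.32 log units; beyond the scatter)). The step from compound 1 to compound 2 is also small (a 1.2-fold higher number from compound 1 to compound 2 (0.10 log units; within the scatter)). In short, swapping the group on that nitrogen, whether ring, chain or benzyl, has moved the number very little so far.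

Compound 4 `O=C(Nc1ccc(NCc2ccc3cn[nH]c3c2)cc1Cl)c1cc(Cl)ccc1O` keeps the benzyl-type linkage of compound 3 and changes only the aromatic ring at its end: 1H-indazol-6-yl in place of 4-bromophenyl on a saturated chain carbon bound to a nitrogen on an aromatic ring. Among the compounds with values here, no measured pair tests this exact swap, so the nearest guide is the general flatness of the earlier steps, which argues for no step beyond the scatter in this assay. The number for compound 4 is therefore expected to sit close to that of compound 3, with a 1.2-fold higher number from compound 3 to compound 4 (0.09 log units; within the scatter) as the estimated step. Compound 4 is estimated at 50000 nM, within a range of 20000 nM to 120000 nM.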

Compound 4, half-maximal cytotoxic concentration: 45300 nM
Compound 4: the middle estimate sits 1.1-fold (0.04 log units) above what was measured; measured number inside the range.
By their numbers in this assay, from the lowest: compounds 3, 4, 1 and 2 (each within the scatter of the next, the first and the last beyond it).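

In this assay, putting 1H-indazol-6-yl in place of 4-bromophenyl on a saturated chain carbon bound to a nitrogen on an aromatic ring gives a 1.1-fold higher number from compound 3 to compound 4 (0.04 log units; within the scatter). The earlier compounds shown here exchanged the whole group on the amino nitrogen, whereas this change keeps the linkage and alters only the aromatic end, and it shows that this end can lose its bromine and gain a five-membered aromatic ring with 2 hetero atoms, a hydrogen-bond donor and a hydrogen-bond acceptor while the number stays within the scatter. No accompanying measurement explains why such a large change in the group leaves the number so flat, so this remains an observation about these two compounds only.

Still open, on these data alone, is whether a more different end group, such as a carboxylic acid or a primary amine on the aromatic ring, or a longer chain in place of the saturated chain carbon, would move the number beyond the scatter. The compounds shown also leave open how cell tolerance responds to changes elsewhere on the shared core, since all of them keep it unchanged.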